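The compounds below may be only part of what the source reports. "The series", "measured", "known", "first", "only" and "open" are said of these compounds alone.

Compound 1 `Fc1cccc(-c2nc(Nc3ccccc3)c3cc(F)ccc3n2)c1`: in a functional assay on HL-60 cells (Homo sapiens) for cytotoxicity, read by MTT assay, with a stated time of 48 h (a higher number here means a weaker inhibitor, a lower number a stronger inhibitor), compound 1 gives 48300 nM.
Compound 2 `Fc1cccc(Nc2nc(-c3cccc(F)c3)nc3ccc(F)cc23)c1`: in this assay compound 2 gives 43100 nM.
Compound 3 `Fc1cccc(-c2nc(Nc3cccc(Cl)c3)c3cc(F)ccc3n2)c1`: in this assay compound 3 gives > 50000 nM, which is a limit of the assay and not a number.

Compound 3 stands at the edge of what was measured: it sits at the limit of > 50000 nM in this assay, at which 1 of the 3 values shown sits, so its place on the numbers shown is known only as a limit. Going by the values given here, the steps reaching it are floors, an at least 1.0-fold higher number from compound 1 to compound 3 (0.01 log units; that floor lies within the scatter) and an at least 1.1-fold higher number from compound 2 to compound 3 (0.06 log units; that floor lies within the scatter), and the one step between two numbered values, a 1.1-fold lower number from compound 1 to compound 2 (0.05 log units; within the scatter), is also within the scatter. Nothing among these three compounds moves beyond the scatter.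

Compound 4 `Fc1cccc(-c2nc(Nc3ccccc3Cl)c3cc(F)ccc3n2)c1` differs from compound 3 by 2-chlorophenyl in place of 3-chlorophenyl on a nitrogen on an aromatic ring. Among the compounds with values here, no measured step moves a chloro around the ring on that nitrogen; the steps that exist only add fluoro or chloro to that ring, or swap one for the other, and each is small. The expectation for compound 4 is therefore a step of no size beyond the scatter, a number no higher from compound 3 to compound 4 (the limit leaves the size open), with a fair chance that the assay again reports only a limit. Compound 4 is estimated at 50000 nM, within a range of 25000 nM to 100000 nM.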

Compound 4, half-maximal inhibitory concentration: > 50000 nM
Compound 4 was reported as a limit; the forecaster's own chance of this, stated with the estimate: 55%; the middle value sits exactly at the limit.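

Moving the chloro from 3-chlorophenyl to 2-chlorophenyl on the nitrogen gives no number in this assay, and the step from compound 3 to compound 4 cannot be read, with a limit at each end. The two floors that can be read, an at least 1.0-fold higher number from compound 1 to compound 4 (0.01 log units; that floor lies within the scatter) and an at least 1.1-fold higher number from compound 2 to compound 4 (0.06 log units; that floor lies within the scatter), show no separation from compound 1 or compound 2 beyond the scatter. What is new is that the chloro in this second place also ends at the limit, so both chlorophenyl compounds now share it: the limit of > 50000 nM in this assay, at which 2 of the 4 values shown sit.

As far as these compounds go, how far compound 3 and compound 4 truly lie from each other stays open, as neither has a number in this assay. Also open, from the compounds shown here alone, is whether another group on that ring, such as an amine, a carboxylic acid or a methoxy group, would give a value clearly apart from those of compound 1 and compound 2.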